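Adding bromo to the phenyl of compound 2

This account rests on a few compounds, and the source may have more. Where it says the series, first, only, none or still open, it means among the compounds named here.

Compound 1 `CC(=O)OCCC1S/C(=N\N=C\c2c(-c3ccccc3)[nH]c3ccccc23)NC1=O`: 37100 nM
Compound 2 `CCC1S/C(=N\N=C\c2c(-c3ccccc3)[nH]c3ccccc23)NC1=O`: > 50000 nM

In an ADME assay on BJ cells (Homo sapiens) for cytotoxicity, read by fluorescence, with a stated time of 24 h (on this read-out lower numbers stand for stronger inhibition and higher numbers for weaker inhibition), compound 2 stands at > 50000 nM, which is a limit of the assay and not a number. Compound 3 `CCC1S/C(=N\N=C\c2c(-c3ccc(Br)cc3)[nH]c3ccccc23)NC1=O` differs from compound 2 by bromo in place of hydrogen on an aromatic carbon. Among the measured compounds shown here, the only measured step, an at least 1.3-fold higher number from compound 1 to compound 2 (0.12 log units; that floor lies within the scatter), changes a saturated chain rather than an aromatic carbon, and it stays within the scatter. No step beyond the scatter is expected in this assay, and the limit leaves its direction open. The expected size is an at least 1.1-fold lower number from compound 2 to compound 3 (0.04 log units; that floor lies within the scatter). For compound 3 the estimate is 45000 nM, with an expected range from 20000 nM to 90000 nM.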

Compound 3, half-maximal inhibitory concentration: 7450 nM
Estimate against measurement, compound 3: 6.0-fold (0.78 log units) above, and the stated range ends above it.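

In this assay, the change from phenyl to 4-bromophenyl gives an at least 6.7-fold lower number from compound 2 to compound 3 (0.82 log units; beyond the scatter), the first step shown that lies beyond the scatter. The aromatic carbon para to a large group therefore responds to bromo, whereas the earlier step on the saturated chain stayed within the scatter. That step can be read only as a floor, because compound 2 stands at a limit and not a number: the limit of > 50000 nM in this assay, at which 1 of the 3 values shown sits.

The compounds shown leave open whether chloro, methoxy or an amine on this aromatic carbon would lower the number as bromo does. As far as these compounds go, whether bromo would act likewise alongside the acetoxy chain of compound 1 also remains open.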